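From thiophen-2-yl to phenyl on a shared core

The compounds below may be only part of what the source reports. "The series", "measured", "known", "first", "only" and "open" are said of these compounds alone.

Compound 1 `Cc1nc(N)c2c(-c3ccco3)cn([C@@H]3O[C@H](CO)[C@@H](O)[C@H]3O)c2n1` and compound 2 `Cc1nc(N)c2c(-c3ccoc3)cn([C@@H]3O[C@H](CO)[C@@H](O)[C@H]3O)c2n1` and compound 3 `Cc1nc(N)c2c(-c3cccs3)cn([C@@H]3O[C@H](CO)[C@@H](O)[C@H]3O)c2n1` share one core and differ only in the aromatic ring on one carbon. In a functional assay on HCT-116 cells (Homo sapiens), read by MTT assay, with a stated time of 72 h (on this read-out lower numbers stand for stronger inhibition and higher numbers for weaker inhibition), compound 1 gives > 20000 nM as a limit and not a number. Compound 2 likewise gives > 20000 nM as a limit. Compound 3 gives > 20000 nM as a limit too, so it has no exact place on the scale. All three sit together at the same point, as the limit of > 20000 nM in this assay, at which 3 of the 3 values shown sit, records.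

For the measured compounds named here, the next structure is compound 4 `Cc1nc(N)c2c(-c3ccccc3)cn([C@@H]3O[C@H](CO)[C@@H](O)[C@H]3O)c2n1` with phenyl in place of thiophen-2-yl on an aromatic carbon as its only change.

Going by the values given here, three measured steps bear on this swap of one aromatic ring for another. They are a step that the two limits leave unreadable from compound 1 to compound 2 and a step that the two limits leave unreadable from compound 1 to compound 3 and a step that the two limits leave unreadable from compound 2 to compound 3 and none has a size that can be read. They therefore give no direction for the new swap, and no step beyond the usual scatter is expected. The estimated step is a number no higher from compound 3 to compound 4 (the limit leaves the size open) in this assay and it may well end in the same limit. For compound 4 the expected value is 20000 nM with an estimated range from 7000 nM to 40000 nM around it.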

Compound 4, half-maximal inhibitory concentration: > 100000 nM
Compound 4: only a limit was reported; the forecaster's own chance of this, stated with the estimate: 85%; at least 5.0-fold (0.69 log units) between middle value and limit.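

Compound 4, like compound 1, compound 2 and compound 3, is reported only as a limit, so none of the steps from those three compounds to compound 4 can be read. The compounds shown leave open whether any of these aromatic rings on the shared core gives an exact inhibitory value in this assay and how such values would compare.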